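The source may report more compounds than this note shows. Statements on the series, on what has been measured and on what is new or still open speak of the compounds shown alone.

Measured compounds:
- Compound 1 `Cc1cc(Nc2nc(NCc3ccc(F)cc3F)nc3ccccc23)n[nH]1`: 200 nM
- Compound 2 `Fc1ccc(CNc2nc(Nc3cc(C4CC4)[nH]n3)c3ccccc3n2)c(F)c1`: 4.7 nM
- Compound 3 `Cc1cc(Nc2nc(NCc3ccc(F)cc3F)nc3ccc(F)cc23)n[nH]1`: 44 nM

In an assay for inhibition of high affinity nerve growth factor receptor (Homo sapiens), read by HTRF, with a stated time of 30 min, in the presence of a further agent that is not named here (on this read-out lower numbers stand for stronger inhibition and higher numbers for weaker inhibition), compound 3 stands second highest of the three numbers; its nearest neighbour is compound 1, which gives 200 nM, and the furthest is compound 2, which gives 4.7 nM. Compound 4 `Fc1ccc(CNc2nc(Nc3cc(C4CC4)[nH]n3)c3cc(F)ccc3n2)c(F)c1` differs from compound 3 in one place: cyclopropyl in place of methyl on an aromatic carbon.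

The same replacement has already been made once in the series, as the step from compound 1 to compound 2, which read a 43-fold lower number from compound 1 to compound 2 (1.63 log units; beyond the scatter). The other step, a 4.5-fold lower number from compound 1 to compound 3 (0.66 log units; beyond the scatter), supplies the fluoro already present in compound 3 and compound 4, so the fluoro and the cyclopropyl have each been seen once, but never together. If the two effects add, the step to compound 4 in this assay is expected to be a large drop, of the order seen from compound 1 to compound 2, that is a 29-fold lower number from compound 3 to compound 4 (1.47 log units; beyond the scatter). Compound 4 is therefore expected to give about 1.5 nM, with a range from 0.5 nM to 5 nM.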

Compound 4, half-maximal inhibitory concentration: 59 nM
For compound 4 the middle estimate is 39-fold (1.59 log units) below the measured one, outside the stated range (above it).
By their numbers in this assay, from the lowest: compound 2; then compounds 3 and 4 (each within the scatter of the next); then compound 1.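

In this assay, the gain from cyclopropyl in place of methyl on this aromatic carbon depends on the rest of the molecule: with the fluoro on the core the change reads a 1.3-fold higher number from compound 3 to compound 4 (0.13 log units; within the scatter), so the earlier gain does not carry over: the same change on two cores in this assay, a 43-fold lower number (1.63 log units; beyond the scatter) from compound 1 to compound 2 and a 1.3-fold higher number (0.13 log units; within the scatter) from compound 3 to compound 4, 57-fold (1.76 log units) apart, beyond the scatter of two such steps. The fluoro likewise changes direction with the group at this position, since with cyclopropyl present it reads a 13-fold higher number from compound 2 to compound 4 (1.10 log units; beyond the scatter), against a lower number with methyl present: the same change on two cores in this assay, a 4.5-fold lower number (0.66 log units; beyond the scatter) from compound 1 to compound 3 and a 13-fold higher number (1.10 log units; beyond the scatter) from compound 2 to compound 4, 57-fold (1.76 log units) apart, beyond the scatter of two such steps. The two replacements therefore do not add across these four compounds, and the lowest number, 4.7 nM, belongs to compound 2, which has cyclopropyl without the fluoro.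

What lies behind this dependence cannot be read from these compounds. From the compounds shown here alone, it remains open whether chloro or methoxy in place of the fluoro would cancel the cyclopropyl gain too, and how ethyl or isopropyl on this aromatic carbon would behave on either core.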